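Hydroxybutyl for phenyl on two related cores

The source may report more compounds than this note shows. Statements on the series, on what has been measured and on what is new or still open speak of the compounds shown alone.

Compound 3 `CSc1nc(NCc2ccccc2)c2cccnc2n1` and compound 1 `CSc1nc(NCCCCCO)c2cccnc2n1` share one core; compound 2 `CSc1nc(NCc2ccccc2)c2ccccc2n1` and the unmeasured compound 4 `CSc1nc(NCCCCCO)c2ccccc2n1` share another, and the difference between the two cores is not broken down here. In a functional assay on MCF7 cells (Homo sapiens) for cytotoxicity, read by MTT assay, with a stated time of 72 h (on this read-out lower numbers stand for higher toxicity in this test and higher numbers for lower toxicity in this test), compound 3 gives only a limit, > 100000 nM. In this assay compound 1 likewise gives a limit, > 100000 nM. In this assay compound 2 also gives a limit, > 100000 nM. The change from compound 3 to compound 1 is 4-hydroxybutyl in place of phenyl on a saturated chain carbon bound to a nitrogen on an aromatic ring and its step is a step that the two limits leave unreadable from compound 3 to compound 1, because of the limit of > 100000 nM in this assay, at which 3 of the 3 values shown sit. The change from compound 2 to compound 4 is the same change, (4-hydroxybutyl in place of phenyl on a saturated chain carbon bound to a nitrogen on an aromatic ring), at the same place. For compound 4 the expectation in this assay rests on compound 2 sitting at the limit > 100000 nM and on the first pair both sitting at the limit; the expected step is a step that the limit leaves unreadable from compound 2 to compound 4, meaning no readable movement. Compound 4 is therefore estimated at 150000 nM, with a range from 50000 nM to 500000 nM, most likely reported as a limit only.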

Compound 4, concentration lethal to 50% of the cells: > 100000 nM
Compound 4: a limit, no number (the forecaster's own chance of this, stated with the estimate: 85%); the middle value is on the limit's open side.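

In this assay compound 4 gives only a limit, > 100000 nM. No step can be read from compound 2 to compound 4, nor any other step among these compounds: the limit of > 100000 nM in this assay, at which 4 of the 4 values shown sit. The compounds shown leave open whether 4-hydroxybutyl in place of phenyl, or the difference between the two cores, changes the read-out in this assay at all.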